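This account rests on a few compounds, and the source may have more. Where it says the series, first, only, none or still open, it means among the compounds named here.

Measured compounds:
Compound 1, `CC1=C(C(=O)CC(C)C)C(c2cccs2)NC(=O)N1`, gives 18%.
Compound 2, `CCNC(=O)C1=C(C)NC(=O)NC1c1cccs1`, gives 4%.

Both numbers come from an assay on membranes from HeLa cells for displacement of a labelled ligand from adenosine receptor A3 (Homo sapiens), read by scintillation counting, with a stated time of 180 min, tested at 1 uM; a lower number here means less inhibition, a higher number more inhibition at the concentration tested (going by the name of the read-out). Compound 2 stands lowest of the two numbers; its nearest neighbour is compound 1, and the step of a number 14 percentage points lower from compound 1 to compound 2 (beyond the scatter) lies beyond the scatter. That step came from putting ethylamino in place of isobutyl on a carbonyl carbon, so it shows that changes at this position on the shared core can move the read-out, though only by a modest amount.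

Compound 3, `CC1=C(c2ncc(C)o2)C(c2cccs2)NC(=O)N1`, has not yet been measured. It differs from compound 2 in one place: 5-methyl-1,3-oxazol-2-yl in place of ethylcarbamoyl on a double-bonded ring carbon. Going by the values given here, this is a larger change than the one between compound 1 and compound 2, since the whole ethylcarbamoyl is replaced rather than only the group on its carbonyl carbon, and no measured step tells which way such a swap moves the number. With compound 2 already near the bottom of the scale, any movement would more likely be upward than downward. The estimated step of a number 8 percentage points higher from compound 2 to compound 3 (within the scatter) is therefore small and uncertain. For compound 3 the expected value is 12%, with a range from 0% to 35%.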

Compound 3, a percentage reported as inhibition, at one concentration (the size of the read-out at that concentration, not a potency): 1%
Compound 3: middle estimate off by 11 percentage points, on the high side; low and high end bracket the measured number.
By their numbers in this assay, from the lowest: compounds 3 and 2 (each within the scatter of the next); then compound 1.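

In this assay, going by these compounds alone, a ring stands at this position for the first time, and the exchange of ethylcarbamoyl for 5-methyl-1,3-oxazol-2-yl gives a number 3 percentage points lower from compound 2 to compound 3 (within the scatter) so the open amide chain and the five-membered aromatic ring cannot be told apart by this measurement. Set against isobutylcarbonyl, the same ring gives a number 17 percentage points lower from compound 1 to compound 3 (beyond the scatter) and so matches what ethylcarbamoyl already showed: two quite different replacements of the isobutylcarbonyl, one with a ring and one without, both give numbers beyond the scatter from compound 1. The swap also changes the hydrogen-bond count, from 1 donor and 1 acceptor to 0 donors and 2 acceptors, yet no difference beyond the scatter goes with it, and nothing available explains why these numbers fall where they do.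

On these data alone, all three compounds show only slight inhibition at the single concentration tested, so it remains open whether any group at this position can raise the number well beyond that of compound 1. A primary amine or a carboxylic acid here, or a longer ketone chain than isobutylcarbonyl, would test this, as would a change to the thiophen-2-yl group.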